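The compounds below may be only part of what the source reports. "The series", "measured", "known", "first", "only" and "open" are said of these compounds alone.

Of the compounds shown here, three have been measured so far in a functional assay, tested at 200 ug/mL; on this read-out lower numbers stand for a stronger effect and higher numbers for a weaker effect at the one concentration tested. Compound 1, `CCOC(=O)C1=C(C)N(c2ccccc2)C=CC1c1ccccc1[N+](=O)[O-]`, gives -26.9%. Compound 2, `COC(=O)C1=C(C)N(c2ccccc2)C=CC1c1ccccc1`, gives -23% in this assay. Compound 3, `COC(=O)C1=C(C)N(c2ccc(OC)cc2)C=C(C)C1c1ccccc1`, gives -22.6% in this assay, the highest of the three numbers; its nearest neighbour is compound 2, whose number lies within the scatter, and its furthest is compound 1, whose number also lies within the scatter. Taken together, the three numbers show no difference that can be separated from the noise of repeated measurements.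

Compound 4, `COC(=O)C1=C(C)N(c2ccccc2)C=C(C)C1c1ccccc1`, has not yet been measured in this assay. It differs from compound 3 in one place: hydrogen in place of methoxy on an aromatic carbon. In other words, hydrogen in place of methoxy on an aromatic carbon, para to a large group.

Going by the values given here, no pair of measured compounds differs in a single place, so there is no step from which to read off what this change does. Given that compound 3, compound 2 and compound 1 all lie within the scatter of one another, the step from compound 3 to compound 4 in this assay is expected to be small, a number 0.1 percentage points higher from compound 3 to compound 4 (within the scatter), with no direction beyond the scatter. The estimate for compound 4 in this assay is -22.5%, with a range from -33% to -12%.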

Compound 4, a percentage reported as activity, at one concentration (the size of the read-out at that concentration, not a potency): -33.1%
For compound 4 the middle estimate is 10.6 percentage points above the measured one, outside the stated range (below it).
By their numbers in this assay, from the lowest: compounds 4, 1, 2 and 3 (each within the scatter of the next, the first and the last beyond it).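

Read in this assay, hydrogen in place of methoxy on an aromatic carbon, para to a large group, gives a number 10.5 percentage points lower from compound 3 to compound 4 (beyond the scatter), so this place on the ring responds to the change 4-methoxyphenyl to phenyl, which the earlier numbers, all within the scatter of one another, could not show. A second single change, methyl in place of hydrogen on a double-bonded ring carbon, gives a number 10.1 percentage points lower from compound 2 to compound 4 (beyond the scatter), so each of the two changes on its own separates compound 4 from a compound that differs from it in one place, and in both cases toward a stronger effect at the one concentration tested. Nothing in the data shown gives a reason for either step.

Going by these compounds, it remains open whether the step belongs to methoxy alone or would also follow from a chlorine, a hydroxyl or an ethoxy group on that aromatic carbon. On these data alone, it is also open whether methoxy carries the same weight on a core with hydrogen rather than methyl on the double-bonded ring carbon, and a reading at a single concentration says nothing about potency.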